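A few compounds are considered here, and "the series" means these few. Any claim that something is new, unique, unknown or untested is made for them only; others in the source may bear on it.

Compound 1 `COc1ccc(CCCN2CCC(CNC(c3ccccc3)c3ccccc3)CC2)cc1`: 2800 nM
Compound 2 `COc1ccc(CCCN2CCC(C(O)CC(c3ccccc3)c3ccccc3)CC2)cc1`: 1500 nM
Compound 3 `Clc1ccc(CCCN2CCC(COC(c3ccccc3)c3ccccc3)CC2)cc1`: 500 nM

In a functional assay on cells (T-cell line, Homo sapiens) for inhibition (on this read-out lower numbers stand for stronger inhibition and higher numbers for weaker inhibition), compound 3 gives 500 nM, the lowest of the three numbers, and its gaps to compound 2 and compound 1 lie beyond the scatter. Compound 4 `CCN1CCC(COC(c2ccccc2)c2ccccc2)CC1` differs from compound 3 as follows: hydrogen in place of 4-chlorobenzyl on a saturated chain carbon, two bonds along the chain from an amine nitrogen in a ring. Cut one bond further out, this change reads 3-(4-chlorophenyl)propyl to ethyl. Within the data shown here, no measured pair tests this change, and all three measured compounds keep a long chain ending in an aromatic ring. A weaker result is therefore expected, with a rise in the number well beyond the scatter, a 16-fold higher number from compound 3 to compound 4 (1.20 log units; beyond the scatter). For compound 4 the estimated value is 8000 nM, with an expected range of 2000 nM to 30000 nM.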

Compound 4, half-maximal inhibitory concentration: > 20000 nM
Compound 4 was reported as a limit; the forecaster's own chance of this, stated with the estimate: 25%; at least 2.5-fold (0.39 log units) between middle value and limit.
By their numbers in this assay, from the lowest: compound 3; then compounds 2 and 1 (each within the scatter of the next). At a limit, above all of these: compound 4.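

In this assay, compound 4 gives > 20000 nM, which is a limit of the assay and not a number. Cutting 3-(4-chlorophenyl)propyl back to ethyl brings an at least 40-fold higher number from compound 3 to compound 4 (1.60 log units; beyond the scatter), so the outer part of this chain matters greatly for inhibition, something no earlier pair could test. With the 4-chlorobenzyl part gone, activity falls out of the measurable range.

On these data alone, what remains open is which part of that group counts: the aromatic ring, the chlorine or the chain length. A plain butyl chain or a 3-phenylpropyl group in this place would begin to separate them.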